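This account rests on a few compounds, and the source may have more. Where it says the series, first, only, none or still open, it means among the compounds named here.

Values in a functional assay on DU-145 cells (Homo sapiens) for cytotoxicity, read by sulforhodamine B assay, with a stated time of 48 h; on this read-out higher numbers stand for weaker inhibition and lower numbers for stronger inhibition:

compound 1 `CCc1ccc(-c2nc(C(=O)c3cc(OC)c(OC)c(OC)c3)cs2)cc1`: 31 nM
compound 2 `COc1cc(NC(=O)[C@@H]2CSC(c3cc(OC)c(OC)c(OC)c3)N2)cc(OC)c1OC`: > 20000 nM
compound 3 `COc1cc(NC(=O)[C@@H]2CSC(c3ccccc3)N2)cc(OC)c1OC`: > 20000 nM

Compound 1 carries the only number shown in this assay. For compound 2 the value is a limit of this assay, not a number. For compound 3 the value is likewise a limit. Within the data shown here, two of the three results therefore sit at the same boundary, as noted in the limit of > 20000 nM in this assay, at which 2 of the 3 values shown sit, and no step between measured compounds can be read from them; of compound 2 and compound 3 one can say only that both fall at the limit, nothing about their order.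

The next compound, compound 4 `COC(=O)c1ccc(-c2nc(C(=O)c3cc(OC)c(OC)c(OC)c3)cs2)cc1`, keeps the core of compound 1 and changes a single group: methoxycarbonyl in place of ethyl on an aromatic carbon. Among the measured compounds shown here, no measured pair shows what this change does, so any expectation rests on compound 1 alone and on the size of the change itself.

In this assay compound 4 is expected to be weaker than compound 1, with a step of a 9.7-fold higher number from compound 1 to compound 4 (0.99 log units; beyond the scatter) that goes beyond the usual scatter. The estimate for compound 4 is 300 nM, with a range from 50 nM to 3000 nM.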

Compound 4, half-maximal inhibitory concentration: > 20000 nM
Compound 4 gave a limit, no number; the forecaster's own chance of this, stated with the estimate: 5%; middle value at least 66-fold (1.82 log units) away from the limit.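

In this assay compound 4 gives > 20000 nM, which is a limit of the assay and not a number. Among these compounds, this gives the first readable step, an at least 640-fold higher number from compound 1 to compound 4 (2.80 log units; beyond the scatter), and it shows that the position on the aromatic carbon para to a large group does not tolerate every substituent: on the core of compound 1, methoxycarbonyl in place of ethyl is enough to lose any measurable number in this read-out. The step has a lower bound only, so its true size stays unknown, and the series still holds a single number, that of compound 1: the limit of > 20000 nM in this assay, at which 3 of the 4 values shown sit.

As far as these compounds go, whether a propyl chain, a methoxy group, an amine or a carboxylic acid at this position would keep a number in this assay remains open. A single pair also cannot say whether ethyl is unusually well suited to this position or methoxycarbonyl is unusually poor there, and a group such as acetyl or a methyl ester placed elsewhere on the same ring would be needed to separate the two readings.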